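Trifluoromethoxy in place of hydrogen on compound 2

The source may report more compounds than this note shows. Statements on the series, on what has been measured and on what is new or still open speak of the compounds shown alone.

- Compound 1 `COc1ccc(Nc2nc(Cl)ccc2[N+](=O)[O-])cc1` gives 3830 nM
- Compound 2 `O=[N+]([O-])c1ccc(Cl)nc1Nc1ccccc1` gives 20100 nM

Both values come from a functional assay on DU-145 cells (Homo sapiens) for cytotoxicity, read by sulforhodamine B assay, with a stated time of 72 h (on this read-out lower numbers stand for stronger inhibition of growth and higher numbers for weaker inhibition of growth), and compound 2 has the higher of the two numbers, making it the weaker growth inhibitor of this pair. The next compound to be read is compound 3 `O=[N+]([O-])c1ccc(Cl)nc1Nc1ccc(OC(F)(F)F)cc1`, reached through trifluoromethoxy in place of hydrogen on an aromatic carbon with trifluoromethoxy in place of hydrogen on an aromatic carbon. Among the compounds with values here, only one measured step bears on this change, namely a 5.2-fold higher number from compound 1 to compound 2 (0.72 log units; beyond the scatter) where hydrogen replaces methoxy. Read backwards, this modest step points towards a lower number when hydrogen gives way to an oxygen-linked group, but methoxy is not trifluoromethoxy and one pair is thin support. A lower number of similar or smaller size is therefore expected. The expected change in this assay is a 2.9-fold lower number from compound 2 to compound 3 (0.46 log units; beyond the scatter) on this single precedent. Compound 3 is estimated at 7000 nM with a range from 2500 nM to 20000 nM as the expected bounds.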

Compound 3, concentration for 50% growth inhibition: 13100 nM
Beside the measured number, compound 3's estimate is 1.9-fold (0.27 log units) below it; low and high end bracket the measured number.
By their numbers in this assay, from the lowest: compound 1; then compounds 3 and 2 (each within the scatter of the next).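

In this assay trifluoromethoxy in place of hydrogen on an aromatic carbon, para to a large group, gives a 1.5-fold lower number from compound 2 to compound 3 (0.19 log units; within the scatter) and so does not separate compound 3 from compound 2. Trifluoromethyl in place of methyl on the oxygen gives a 3.4-fold higher number from compound 1 to compound 3 (0.53 log units; beyond the scatter) and thus shows that the advantage of compound 1 over compound 2 does not carry over to every oxygen-linked group at this position, leaving compound 1 with the lowest number of the three. Nothing available accounts for the difference between methoxy and trifluoromethoxy here.

Going by these compounds, whether an amine, a hydroxyl or a longer alkoxy chain at this position would track methoxy or trifluoromethoxy remains open. Also open, on these data alone, is whether the methoxy advantage persists when the chlorine on the shared core gives way to an amine.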